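Swapping thiophene for pyridine on a shared pyridine core

A few compounds are considered here, and "the series" means these few. Any claim that something is new, unique, unknown or untested is made for them only; others in the source may bear on it.

Measured compounds:
Compound 1 `Oc1ccc(-c2cc(-c3ccc(Cl)cc3)nc(-c3ccsc3)c2)cc1` — 4860 nM
Compound 2 `Oc1cccc(-c2cc(-c3ccc(Cl)cc3)nc(-c3ccsc3)c2)c1` — 11200 nM
Compound 3 `Oc1cccc(-c2cc(-c3ccsc3)nc(-c3cccc(Cl)c3)c2)c1` — 3180 nM

In an ADME assay on HEK293 cells (Homo sapiens) for cytotoxicity, read by CCK-8 assay and cell counting, with a stated time of 2 days (on this read-out higher numbers stand for weaker inhibition and lower numbers for stronger inhibition), compound 2 gives the highest of the three numbers, meaning it is the weakest inhibitor of cell growth measured here. Moving the hydroxyl on the phenyl ring gave a 2.3-fold higher number from compound 1 to compound 2 (0.36 log units; beyond the scatter), and moving the chlorine on the other phenyl ring gave a 3.5-fold lower number from compound 2 to compound 3 (0.55 log units; beyond the scatter). Both steps are modest and both concern substituent position, not the heteroaromatic ring.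

Compound 4 `Oc1cccc(-c2cc(-c3ccncc3)nc(-c3ccc(Cl)cc3)c2)c1` differs from compound 2 in one place: pyridin-4-yl in place of thiophen-3-yl on an aromatic carbon. Among the measured compounds shown here, no measured step touches the thiophene ring, so the two known steps give only a sense of scale; changes of one group on this core have moved this assay by modest amounts in either direction. Compound 4 is therefore expected to stay close to compound 2, with an estimated 1.2-fold lower number from compound 2 to compound 4 (0.09 log units; within the scatter) that may not exceed the scatter. The estimate for compound 4 is 9000 nM, within 3500 nM to 25000 nM.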

Compound 4, half-maximal inhibitory concentration: 2890 nM
Beside the measured number, compound 4's estimate is 3.1-fold (0.49 log units) above it; the measured number lies below the stated range.
By their numbers in this assay, from the lowest: compounds 4, 3 and 1 (each within the scatter of the next); then compound 2.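

In this assay, pyridin-4-yl in place of thiophen-3-yl gave a 3.9-fold lower number from compound 2 to compound 4 (0.59 log units; beyond the scatter), which shows that the group on the aromatic carbon next to the ring nitrogen also affects this read-out, not only the positions of the hydroxyl and chlorine. This step is also rated modest, and the two groups have the same hydrogen-bond donor and acceptor counts, so those counts do not separate them. Nothing available explains why the number fell with this exchange.

On these data alone, whether the same exchange would shift the number in a similar way alongside the 4-hydroxyphenyl group of compound 1 or the 3-chlorophenyl group of compound 3 remains open. Also open, as far as these compounds go, is how this position would respond to a non-aromatic group, such as an amine or a longer alkyl chain.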